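The compounds below may be only part of what the source reports. "The series", "measured", "known", "first", "only" and "open" are said of these compounds alone.

Compound 1 `Fc1ccc2nc(-c3ccccc3)nc(Nc3ccccc3)c2c1` carries an unsubstituted phenyl on the ring nitrogen. In a functional assay on HL-60 cells (Homo sapiens) for cytotoxicity, read by MTT assay, with a stated time of 48 h (on this read-out lower numbers stand for stronger inhibition and higher numbers for weaker inhibition), compound 1 gives only a limit, > 50000 nM. Compound 2 `COc1ccccc1Nc1nc(-c2cccc(F)c2)nc2ccc(F)cc12` gives in this assay likewise a limit, > 50000 nM. Compound 3 `Fc1ccc(Nc2nc(-c3cccc(F)c3)nc3ccc(F)cc23)cc1` stands in this assay at a limit as well, > 50000 nM. The step that the two limits leave unreadable from compound 2 to compound 3 is thus unreadable, both ends resting at the limit at which all values shown sit (the limit of > 50000 nM in this assay, at which 3 of the 3 values shown sit). Compound 4 `Fc1cccc(-c2nc(Nc3cccc(Cl)c3)c3cc(F)ccc3n2)c1` differs from compound 3 by 3-chlorophenyl in place of 4-fluorophenyl on a nitrogen on an aromatic ring. Within the data shown here, no measured step has a readable size, so no direction in this assay can be drawn from them. The expected step that the limit leaves unreadable from compound 3 to compound 4 is accordingly none readable beyond the scatter. For compound 4 the estimated value in this assay is 60000 nM, with a range from 15000 nM to 250000 nM, most likely reported again as a limit.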

Compound 4, half-maximal inhibitory concentration: > 50000 nM
Compound 4: only a limit was reported (the forecaster's own chance of this, stated with the estimate: 80%); the middle value is on the limit's open side.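

The steps from compound 2 to compound 4 and from compound 3 to compound 4 cannot be read, as each compound gives only a limit: the limit of > 50000 nM in this assay, at which 4 of the 4 values shown sit.
In this assay the compounds shown leave open which group on the nitrogen, if any, gives a measurable value.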